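Compound 3 to compound 4: tert-butyl in place of ethyl

A few compounds are considered here, and "the series" means these few. Any claim that something is new, unique, unknown or untested is made for them only; others in the source may bear on it.

In a functional assay on HCT-116 cells (Homo sapiens) for inhibition, read by sulforhodamine B assay, with a stated time of 96 h (on this read-out higher numbers stand for weaker inhibition of growth and lower numbers for stronger inhibition of growth), compound 3 `CCC(O)[C@H](CC)Nc1nc(NCc2ccccn2)c2ncn(C(C)C)c2n1` gives 29000 nM. Compound 2 `CC[C@@H](Nc1nc(NCc2ccccn2)c2ncn(C(C)C)c2n1)C(C)O` gives 18000 nM, and the gap, a 1.6-fold higher number from compound 2 to compound 3 (0.21 log units; within the scatter), lies within the scatter, so these two values cannot be ranked. Compound 1 `CC[C@@H](Nc1nc(NCc2ccccn2)c2ncn(C(C)C)c2n1)C(C)(C)O` reads > 50000 nM, which is a limit of the assay and not a number.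

Compound 4 `CC[C@H](Nc1nc(NCc2ccccn2)c2ncn(C(C)C)c2n1)C(O)C(C)(C)C` carries tert-butyl in place of ethyl on a saturated chain carbon bound to an oxygen on a saturated carbon and a saturated chain carbon. Among the measured compounds shown here, no measured step tests tert-butyl directly, but three bear on the change. Hydrogen in place of methyl gives an at least 2.7-fold lower number from compound 1 to compound 2 (0.44 log units; beyond the scatter), beyond the scatter. Read in reverse, added carbon went with a higher number. Against that, the step of a 1.6-fold higher number from compound 2 to compound 3 (0.21 log units; within the scatter) stays within the scatter, and the floor of an at least 1.7-fold lower number from compound 1 to compound 3 (0.23 log units; that floor lies within the scatter) also lies within it.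

A higher number in this assay is therefore expected, possibly without clearing the scatter. The expected step is a 1.4-fold higher number from compound 3 to compound 4 (0.14 log units; within the scatter). For compound 4 the estimate is 40000 nM, with an expected range of 16000 nM to 50000 nM.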

Compound 4, concentration for 50% growth inhibition: > 50000 nM
Compound 4: a limit, no number (the forecaster's own chance of this, stated with the estimate: 40%); middle value at least 1.2-fold (0.09 log units) away from the limit.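

In this assay compound 4 gives > 50000 nM, which is a limit of the assay and not a number. With tert-butyl in place of ethyl on a saturated chain carbon bound to an oxygen on a saturated carbon and a saturated chain carbon, the readable steps are an at least 1.7-fold higher number from compound 3 to compound 4 (0.23 log units; that floor lies within the scatter) and an at least 2.7-fold higher number from compound 2 to compound 4 (0.44 log units; beyond the scatter), so only the comparison with compound 2 clears the scatter on its floor, while the step between compound 1 and compound 4 cannot be read. Among the compounds shown, the larger 1-ethyl-2-hydroxy-3,3-dimethylbutyl group on the amino nitrogen does not return a measurable number, and the upper end of the series is now shared by compound 1 and compound 4: the limit of > 50000 nM in this assay, at which 2 of the 4 values shown sit.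

On these data alone, how far compound 4 lies from compound 3 stays open, and the limit leaves unsettled whether tert-butyl and ethyl truly differ at this place. Also open, as far as these compounds go, is whether an amine, a carboxylic acid or a longer straight chain in place of tert-butyl at this carbon would give a number in this assay or stay at the limit.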